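Ester loading on the acyclic side chain and buffer stability

This account rests on a few compounds, and the source may have more. Where it says the series, first, only, none or still open, it means among the compounds named here.

Compound 1 `Nc1nc(F)c2ncn(COC(CO)CO)c2n1` carries two free hydroxymethyl arms. In an ADME assay for pharmacokinetics, in phosphate buffer, at pH 8.0 (a higher number here means that the compound lasts longer, a lower number that the compound disappears faster), compound 1 gives 720 h, the higher of the two numbers in hand. Compound 2 `CC(C)C(=O)OCC(COC(=O)C(C)C)OCn1cnc2c(F)nc(N)nc21` is the other measured member, with an isopropylcarbonyl on each arm; in this assay compound 2 gives 120 h, a lower number than compound 1, and the gap lies beyond the usual scatter. Compound 3 `CC(C)C(=O)OCC(CO)OCn1cnc2c(F)nc(N)nc21` is the unmeasured half-way member: against compound 1 the change is isopropylcarbonyl in place of hydrogen on an oxygen on a saturated carbon, the second hydroxymethyl staying free. For the measured compounds named here, no step between measured compounds covers this single change; one ester rather than two places compound 3 between the two measured numbers, so a loss beyond the scatter, yet short of the full distance down to compound 2, is expected. The expected step reads a 2.9-fold lower number from compound 1 to compound 3 (0.46 log units; beyond the scatter). For compound 3 the estimate in this assay is 250 h, with a range from 100 h to 600 h.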

Compound 3, half-life: 336 h
Compound 3: the middle estimate sits 1.3-fold (0.13 log units) below what was measured, within the range that was stated.
By their numbers in this assay, from the lowest: compound 2; then compound 3; then compound 1.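

In this assay a single isopropylcarbonyl on an oxygen on a saturated carbon is already enough for a change beyond the scatter: a 2.1-fold lower number from compound 1 to compound 3 (0.33 log units; beyond the scatter). The reverse change, hydrogen in place of isopropylcarbonyl, also registers when it starts from the diester, with a 2.8-fold higher number from compound 2 to compound 3 (0.45 log units; beyond the scatter), so each single ester change counts by itself and compound 3 takes the middle place among the three members. No measurement in hand speaks to the origin of these steps.

Still open, going by these compounds, is whether these steps belong to isopropylcarbonyl in particular: an acetyl group, a longer acyl chain or an acyl group carrying an amine could give different numbers on the same oxygen. A carbonate in that place is equally untested by the compounds shown here.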